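A few compounds are considered here, and "the series" means these few. Any claim that something is new, unique, unknown or untested is made for them only; others in the source may bear on it.

Compound 3 is `CN(C)c1ccc(/C=C2/SC(N(c3ccccc3)c3ccccc3)=NC2=O)cc1`. In an ADME assay on cells (Homo sapiens) for cytotoxicity, read by sulforhodamine B assay, with a stated time of 48 h (on this read-out lower numbers stand for an effect already at smaller amounts and higher numbers for an effect only at larger amounts of compound), compound 3 gives > 100000 nM, which is a limit of the assay and not a number. Compound 1, `CCN(CC)c1ccc(/C=C2/SC(Nc3ccccc3)=NC2=O)cc1`, gives > 100000 nM in this assay, again a limit. Compound 2, `O=C1N=C(Nc2ccccc2)S/C1=C/c1ccc(N2CCNCC2)cc1`, gives > 100000 nM in this assay, also a limit. (the limit of > 100000 nM in this assay, at which 3 of the 3 values shown sit), so compound 3 stands where every other measured compound stands. The step that the two limits leave unreadable from compound 1 to compound 2 cannot be read. Compound 4 is `CCN(CC)c1ccc(/C=C2/SC(N(c3ccccc3)c3ccccc3)=NC2=O)cc1`; it differs from compound 3 by diethylamino in place of dimethylamino on an aromatic carbon. Among the measured compounds shown here, no measured step bears readably on this change, and compounds 1 and 3 both sit at the limit without a step given between them. For compound 4 the estimate in this assay is 100000 nM, between 40000 nM and 300000 nM. The expected step is a number no higher from compound 3 to compound 4 (the limit leaves the size open), none beyond the scatter.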

Compound 4, half-maximal effective concentration: > 100000 nM
Compound 4: only a limit was reported; the forecaster's own chance of this, stated with the estimate: 85%; the middle value sits exactly at the limit.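

The steps from compound 3 and from compound 1 to compound 4 cannot be read, because all the compounds share one limit: the limit of > 100000 nM in this assay, at which 4 of the 4 values shown sit. As far as these compounds go, whether diethylamino in place of dimethylamino, or phenyl in place of hydrogen, changes the read-out at all stays open.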